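Adding a phenyl to the weakest of three inhibitors

The source may report more compounds than this note shows. Statements on the series, on what has been measured and on what is new or still open speak of the compounds shown alone.

Values in a functional assay on DU-145 cells (Homo sapiens) for inhibition, read by trypan blue exclusion, with a stated time of 96 h; on this read-out lower numbers stand for stronger inhibition of growth and higher numbers for weaker inhibition of growth:
compound 1 `COc1ccccc1/C=C(\C(=O)c1ccc(Cl)cc1)S(=O)(=O)c1ccc(C)cc1` gives 1000 nM
compound 2 `Cc1ccc(CS(=O)(=O)/C(=C/c2ccccc2OCc2ccccc2)C(=O)c2ccc(Cl)cc2)cc1` gives 1000 nM
compound 3 `COc1ccccc1/C=C(\C(=O)c1ccc(Cl)cc1)S(=O)(=O)c1ccc(Br)cc1` gives 10000 nM

Compound 3 has the highest number of the three, so it is the weakest inhibitor of growth here. The untested compound 4 `O=C(/C(=C\c1ccccc1OCc1ccccc1)S(=O)(=O)c1ccc(Br)cc1)c1ccc(Cl)cc1` is compound 3 with one change: phenyl in place of hydrogen on a saturated chain carbon bound to an oxygen on an aromatic ring. Put another way, methoxy becomes benzyloxy. Going by the values given here, no measured pair shows this change alone. Among the compounds with values here, the only measured step is a swap of methyl for bromo, a 10-fold higher number from compound 1 to compound 3 (1.00 log units; beyond the scatter), and compound 4 keeps that bromo, so this step offers a warning rather than a size. Compound 2 also carries benzyloxy and gives 1000 nM, but it differs from compound 3 in another place too. A modest move towards stronger inhibition in this assay is therefore expected, though none beyond the scatter remains possible. The expected change is a 3.3-fold lower number from compound 3 to compound 4 (0.52 log units; beyond the scatter). For compound 4 the estimated value is 3000 nM, with an expected range from 600 nM to 12000 nM.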

Compound 4, concentration for 50% growth inhibition: 1000 nM
Beside the measured number, compound 4's estimate is 3.0-fold (0.48 log units) above it; the measured number falls inside the stated range.
By their numbers in this assay, from the lowest: compounds 1, 2 and 4 (each within the scatter of the next); then compound 3.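

In this assay, going by these compounds alone, methoxy becoming benzyloxy gives a 10-fold lower number from compound 3 to compound 4 (1.00 log units; beyond the scatter) and is the only direct reading of this change, showing that a phenyl on this saturated chain carbon goes with stronger inhibition of growth when bromo is present. With benzyloxy in place, 4-bromophenyl in place of 4-methylbenzyl on the sulfonyl sulfur gives no change at the digits printed from compound 2 to compound 4 (within the scatter) and so leaves no visible loss, while among the methoxy compounds, bromo in place of methyl gave a 10-fold higher number from compound 1 to compound 3 (1.00 log units; beyond the scatter) as a clear loss. Nothing measured here explains why the added phenyl has this effect.

From the compounds shown here alone, it remains open whether a longer chain, an amine or a carboxylic acid in place of the phenyl would hold this level of inhibition. Going by these compounds, it is also open whether the same phenyl would shift the number in a compound keeping methyl instead of bromo.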